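A few compounds are considered here, and "the series" means these few. Any claim that something is new, unique, unknown or untested is made for them only; others in the source may bear on it.

Working notes on the series in a functional assay on A549 cells (Homo sapiens) for antiproliferative activity, read by MTT assay, with a stated time of 72 h; a lower number here means a stronger inhibitor, a higher number a weaker inhibitor. Compound 1 (`COc1cc(CCc2ccccc2)cc(OC)c1O`) gives 10900 nM, compound 2 (`COc1cc(CCc2ccc(Cl)c(Cl)c2)cc(OC)c1O`) gives 13400 nM and compound 3 (`COc1cc(CCc2ccc(F)cc2)cc(OC)c1O`) gives 4150 nM, the lowest of the three numbers. Compound 4 (`COc1cc(CCc2ccc(Br)cc2)cc(OC)c1O`) follows from compound 3 by one change: bromo in place of fluoro on an aromatic carbon, para to a large group.

Among the measured compounds shown here, the only measured step at this place is a 2.6-fold lower number from compound 1 to compound 3 (0.42 log units; beyond the scatter), a modest one, for fluoro in place of hydrogen on an aromatic carbon. For the measured compounds named here, no bromo compound has been measured yet. The values of compound 1 and compound 2 lie within the scatter of each other, so the chloro groups of compound 2 at 13400 nM show no lower number than the unsubstituted ring of compound 1 at 10900 nM. Part of the drop seen with fluoro may therefore be lost with bromo, and a small move toward a higher number is expected, possibly not beyond the scatter. The expected step is a 1.7-fold higher number from compound 3 to compound 4 (0.23 log units; within the scatter). For compound 4 the estimated value is 7000 nM, with an expected range of 2800 nM to 16000 nM.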

Compound 4, half-maximal inhibitory concentration: > 25000 nM
Compound 4: no number, only a limit; the forecaster's own chance of this, stated with the estimate: 3%; middle value at least 3.5-fold (0.55 log units) away from the limit.
By their numbers in this assay, from the lowest: compound 3; then compounds 1 and 2 (each within the scatter of the next). At a limit, above all of these: compound 4.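

In this assay compound 4 stands at a limit of the assay and not at a number: the limit of > 25000 nM in this assay, at which 1 of the 4 values shown sits.

At this place, on an aromatic carbon para to a large group, bromo in place of fluoro gives an at least 6.0-fold higher number from compound 3 to compound 4 (0.77 log units; beyond the scatter), and bromo in place of hydrogen gives an at least 2.2-fold higher number from compound 1 to compound 4 (0.36 log units; beyond the scatter). The result therefore goes past a loss of the fluoro gain, which was a 2.6-fold lower number from compound 1 to compound 3 (0.42 log units; beyond the scatter): from the unsubstituted compound 1, fluoro and bromo move the number in opposite directions.

On these data alone, how far compound 4 lies past its limit remains open, so both steps with bromo have a lower bound only. Also open, as far as these compounds go, is how a single chloro group, an amine or a carboxylic acid would read at this place.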